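The source may report more compounds than this note shows. Statements on the series, on what has been measured and on what is new or still open speak of the compounds shown alone.

Compound 1 `CCS(=O)(=O)Nc1cc(F)cc2c1CCCC2c1c[nH]cn1` carries a fluoro group and an (ethylsulfonyl)amino group on its aromatic ring. In an assay on isolated protein (Cricetulus griseus) for binding affinity to Alpha-1B adrenergic receptor (Mesocricetus auratus), read by radioligand binding (a higher number here means a weaker inhibitor, a lower number a stronger inhibitor), compound 1 gives < 10000 nM, which is a limit of the assay rather than a number. Compound 2 `CCS(=O)(=O)Nc1cc(Cl)cc2c1CCCC2c1c[nH]cn1` differs from compound 1 by chloro in place of fluoro on an aromatic carbon. In this assay compound 2 gives < 10000 nM, again a limit. The step that the two limits leave unreadable from compound 1 to compound 2 cannot be sized because of the limit of < 10000 nM in this assay, at which 3 of the 3 values shown sit. Compound 3 `CS(=O)(=O)Nc1ccc(F)c2c1CCCC2c1c[nH]cn1` rests on a different core; how the core of compound 3 differs from the core of compound 1 is not broken down here. In this assay compound 3 gives < 10000 nM, once more a limit. Compound 4 `CS(=O)(=O)Nc1ccc(Cl)c2c1CCCC2c1c[nH]cn1`, not yet measured, differs from compound 3 by chloro in place of fluoro on an aromatic carbon. This is the same kind of change as that from compound 1 to compound 2, not the same: there the place was meta to a (ethylsulfonyl)amino group, meta to a fused ring and para to a fused ring, whereas here it is ortho to a fused ring, meta to a fused ring and para to a methanesulfonamido group. In this assay the step that the limit leaves unreadable from compound 3 to compound 4 is expected to be small, resting only on the earlier pair, whose step that the two limits leave unreadable from compound 1 to compound 2 could not be read. Compound 4 is therefore estimated at 2000 nM, within 200 nM to 10000 nM.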

Compound 4, inhibition constant: < 10000 nM
Compound 4 gave a limit, no number; the forecaster's own chance of this, stated with the estimate: 80%; the middle value is on the limit's open side.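

No size can be read for the change from fluoro to chloro between compound 3 and compound 4 in this assay, because both results are limits rather than numbers: the limit of < 10000 nM in this assay, at which 4 of the 4 values shown sit.

The compounds shown leave open how strongly each one actually binds, and whether chloro and fluoro differ in either pair.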